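The source may hold more compounds than are shown below. What is called first, only, known or untested is meant among the compounds shown, and "the series" means these compounds.

Compound 1 `COc1ccc(-c2cc(-c3ccc([N+](=O)[O-])cc3)[nH]n2)cc1` gives 14300 nM in a functional assay on SW-620 cells (Homo sapiens) for inhibition, read by MTT assay, with a stated time of 48 h (a lower number here means a stronger inhibitor of growth, a higher number a weaker inhibitor of growth), and compound 2 `COc1ccc(-c2cc(-c3ccc([N+](=O)[O-])cc3)[nH]n2)cc1OC` gives 26400 nM. The change between them, (methoxy in place of hydrogen on an aromatic carbon), made a 1.8-fold higher number from compound 1 to compound 2 (0.27 log units; within the scatter). Compound 3 `Nc1ccc(-c2cc(-c3ccccc3)n[nH]2)cc1` gives 25400 nM in this assay; the difference between the core of compound 3 and the core of compound 1 is not broken down here. Compound 4 `COc1ccccc1-c1cc(-c2ccc(N)cc2)[nH]n1` carries the same kind of change against compound 3, (methoxy in place of hydrogen on an aromatic carbon). The surroundings differ: in compound 4 the place is ortho to a large group, whereas in compound 2 it is ortho to a methoxy group and meta to a large group. A step of about the same size is expected, a 1.3-fold higher number from compound 3 to compound 4 (0.10 log units; within the scatter), resting on the earlier step because a 1.8-fold higher number from compound 1 to compound 2 (0.27 log units; within the scatter) stayed within the scatter. For compound 4 the estimate in this assay is 32000 nM, expected between 12000 nM and 85000 nM.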

Compound 4, concentration for 50% growth inhibition: 21100 nM
Compound 4: middle estimate off by 1.5-fold (0.18 log units), on the high side, and the stated range covers the measured number.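

Methoxy in place of hydrogen on an aromatic carbon gives a 1.2-fold lower number from compound 3 to compound 4 (0.08 log units; within the scatter) in this assay. Set beside the earlier step, the change carries from one core to the other with no difference that can be told apart: the same change on two cores in this assay, a 1.8-fold higher number (0.27 log units; within the scatter) from compound 1 to compound 2 and a 1.2-fold lower number (0.08 log units; within the scatter) from compound 3 to compound 4, 2.2-fold (0.35 log units) apart, within the scatter of two such steps. Going by these compounds alone, this does not show that the change is neutral on every core, since only two pairs are at hand, both steps stay within the scatter, and the place of the methoxy differs between the pairs.

The compounds shown leave open whether a hydroxyl, a carboxylic acid or a longer alkoxy chain at the same place would give a step beyond the scatter. They also leave open how a halogen such as fluorine would read there.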